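From Cyano to Ethoxycarbonyl: An Expectation for Compound 4

The source may report more compounds than this note shows. Statements on the series, on what has been measured and on what is new or still open speak of the compounds shown alone.

Compound 1 `Cc1ccc2nc(C)n(NC(=O)/C(C#N)=C/c3ccccc3)c(=O)c2c1` gives 13000 nM
Compound 2 `Cc1ccc2nc(C)n(NC(=O)/C(C#N)=C/c3ccc(Cl)cc3)c(=O)c2c1` gives 12000 nM
Compound 3 `Cc1ccc2nc(C)n(-n3c(N)c(C#N)c(-c4ccccc4)c(C#N)c3=O)c(=O)c2c1` gives 5000 nM

All three were tested in a functional assay on HeLa cells (Homo sapiens) for cytotoxicity, read by MTT assay, with a stated time of 3 days; a lower number here means a stronger inhibitor, a higher number a weaker inhibitor. Compound 3 stands at the lowest number of the three, and its gap to compound 2 and to compound 1 lies beyond the usual scatter, so it is the strongest of the measured set. Compound 4 `CCOC(=O)c1c(-c2ccccc2)c(C#N)c(=O)n(-n2c(C)nc3ccc(C)cc3c2=O)c1N` has not yet been measured. It differs from compound 3 in one place: ethoxycarbonyl in place of cyano on an aromatic carbon.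

Within the data shown here, only one measured step exists, a 1.1-fold lower number from compound 1 to compound 2 (0.03 log units; within the scatter), and it concerns a chloro on the phenyl ring of a different part of the molecule; it says nothing about exchanging a cyano for an ethoxycarbonyl. Among the measured compounds shown here, no measured pair bears on this change, so no direction beyond the scatter can be derived from the data. Compound 4 is therefore expected to land near compound 3, with the estimate 5500 nM and a wide range from 2000 nM to 16000 nM. The expected step is a 1.1-fold higher number from compound 3 to compound 4 (0.04 log units; within the scatter), which is not expected to exceed the scatter.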

Compound 4, half-maximal inhibitory concentration: 21000 nM
Beside the measured number, compound 4's estimate is 3.8-fold (0.58 log units) below it, outside the stated range (above it).
By their numbers in this assay, from the lowest: compound 3; then compounds 2, 1 and 4 (each within the scatter of the next).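

In this assay the exchange of cyano for ethoxycarbonyl on this aromatic carbon gives a 4.2-fold higher number from compound 3 to compound 4 (0.62 log units; beyond the scatter) and so shows that the group held here matters for the read-out, which the earlier chloro step, made on a different part of the molecule, could not show. The change also has a clear direction: the larger group, with 5 heavy atoms in place of 2, goes with a weaker compound at this carbon, ortho to a phenyl group and ortho to an amino group. Nothing measured here explains why the number rises.

From the compounds shown here alone, two compounds cannot separate the effect of the ester as a whole from that of its ethyl chain, so it stays open how a methyl ester, a carboxylic acid or a primary amide would behave at this carbon. Going by these compounds, it is also open whether the same exchange would give a similar step at the cyano group meta to this position.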